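The source may report more compounds than this note shows. Statements on the series, on what has been measured and on what is new or still open speak of the compounds shown alone.

Measured compounds:
compound 1, `O=C(/C=C/C1=Cc2ccccc2OC1)c1cccc(F)c1`, 52.4%
compound 2, `O=C(/C=C/C1=Cc2ccccc2OC1)c1cccc(Cl)c1`, 51%
compound 3, `Cc1ccc(C(=O)/C=C/C2=Cc3ccccc3OC2)cc1`, 53.1%

In a functional assay on the whole organism for inhibition, with Mus musculus as the target, with a stated time of 1 h, at a dose of 30 mg/kg by the intraperitoneal route (on this read-out higher numbers stand for more inhibition at the one dose given (going by the name of the read-out) and lower numbers for less inhibition), the three measured compounds sit close together. Compound 3 gives the highest of the three numbers, but the step of a number 0.7 percentage points higher from compound 1 to compound 3 (within the scatter) and the step of a number 2.1 percentage points higher from compound 2 to compound 3 (within the scatter) are both within the scatter, so compound 3 cannot be said to have a higher number than the other two; it simply sits with the others. The remaining step, a number 1.4 percentage points lower from compound 1 to compound 2 (within the scatter), is likewise within the scatter.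

Compound 4, `Nc1ccc(C(=O)/C=C/C2=Cc3ccccc3OC2)cc1`, differs from compound 3 in one place: amino in place of methyl on an aromatic carbon. Within the data shown here, no measured step introduces an amino group or any donor into this position, so the three steps on the aryl substituent are the only ones that bear on it, and all of them were within the scatter. The shared core and the enone link are unchanged. Compound 4 is therefore expected to lie within the scatter of compound 3, with an expected step of a number 1.1 percentage points lower from compound 3 to compound 4 (within the scatter) in this assay. Compound 4 is estimated at 52%, in the range 38% to 66%.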

Compound 4, a percentage reported as inhibition, in the whole organism at one dose (the size of the read-out at that dose, not a potency): 52.6%
The estimate for compound 4 lay 0.6 percentage points below the measured number; the range from low to high includes it.
By their numbers in this assay, from the lowest: compounds 2, 1, 4 and 3 (each within the scatter of the next).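

Placing amino in place of methyl on this aromatic carbon, para to a large group, adds a hydrogen-bond donor and a hydrogen-bond acceptor, yet in this assay it gives only a number 0.5 percentage points lower from compound 3 to compound 4 (within the scatter). The 4-aminophenyl compound also cannot be told apart from the two halogen-bearing compounds, with a number 1.6 percentage points higher from compound 2 to compound 4 (within the scatter) and a number 0.2 percentage points higher from compound 1 to compound 4 (within the scatter), so this position accepts a nitrogen-bearing group as well as methyl, at least on this read-out at one dose. No supporting measurement bears on this result.

The compounds shown leave open whether a carboxylic acid, a dimethylamino group or a longer chain at this carbon would also stay within the scatter. They also leave open whether these four compounds would separate at other doses, since a single dose gives no measure of potency.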